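Two ester swaps on a shared core, one half-life to guess

The compounds below may be only part of what the source reports. "The series", "measured", "known", "first", "only" and "open" are said of these compounds alone.

Measured compounds:
- compound 1 `CC(=O)Oc1ccccc1C(=O)O[C@H]1CO[C@H]2[C@@H]1OC[C@H]2OC(=O)c1cccc(O)c1`: 0.015 h
- compound 2 `CCCCC(=O)O[C@@H]1CO[C@H]2[C@@H]1OC[C@@H]2OC(=O)c1ccccc1OC(C)=O`: 0.0117 h
- compound 3 `CC(=O)Oc1ccccc1C(=O)O[C@H]1CO[C@H]2[C@@H]1OC[C@H]2OC(=O)c1ccccc1`: 0.0107 h

In an ADME assay on a cell-free system (plasma, Homo sapiens) for metabolic stability, with Plasma (Rattus norvegicus) as the target, read by HPLC, at pH 7.4 (a lower number here means that the compound disappears faster, a higher number that the compound lasts longer), compound 1 gives 0.015 h, compound 2 gives 0.0117 h and compound 3 gives 0.0107 h. Compound 2 sits in the middle of these three numbers, with a 1.3-fold lower number from compound 1 to compound 2 (0.11 log units; within the scatter) on one side and a 1.1-fold lower number from compound 2 to compound 3 (0.04 log units; within the scatter) on the other; both of those steps lie within the scatter, so the three compounds cannot be told apart on this read-out.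

Compound 4 `CC(=O)Nc1cccc(C(=O)O[C@@H]2CO[C@H]3[C@@H]2OC[C@@H]3OC(=O)c2ccccc2OC(C)=O)c1` has not been measured. It differs from compound 2 by 3-acetamidophenyl in place of butyl on a carbonyl carbon. Within the data shown here, two measured steps bear on this change. The step of a 1.1-fold lower number from compound 2 to compound 3 (0.04 log units; within the scatter) exchanges the same butyl for a plain aromatic ring, and the step of a 1.4-fold lower number from compound 1 to compound 3 (0.15 log units; within the scatter) shows that adding or removing a small group on an aromatic carbon of that ester also left the number within the scatter. Neither move shifted the half-life beyond the scatter, so the expected step of a 1.0-fold higher number from compound 2 to compound 4 (0.01 log units; within the scatter) is essentially none. Compound 4 is therefore estimated at 0.012 h, with a range from 0.006 h to 0.025 h.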

Compound 4, half-life: 0.0583 h
Beside the measured number, compound 4's estimate is 4.9-fold (0.69 log units) below it, outside the stated range (above it).
By their numbers in this assay, from the lowest: compounds 3, 2 and 1 (each within the scatter of the next); then compound 4.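

Among these compounds, putting 3-acetamidophenyl in place of butyl on this carbonyl carbon gives a 5.0-fold higher number from compound 2 to compound 4 (0.70 log units; beyond the scatter) in this assay and is the first change in this set to reach beyond the scatter. An aromatic ring alone does not bring this about: acetamido in place of hydrogen gives a 5.4-fold higher number from compound 3 to compound 4 (0.74 log units; beyond the scatter) while acetamido in place of hydroxy gives a 3.9-fold higher number from compound 1 to compound 4 (0.59 log units; beyond the scatter) and so, among these compounds, the longer half-life goes with the acetamido group and not with the ring itself. No measurement shown gives a reason for this longer half-life.

Still open, as far as these compounds go, is whether the whole acetamido group is needed or whether a simple amine on the same ring would do as much. From the compounds shown here alone, it is also open whether a different group on that ring, such as a carboxylic acid or a methoxy group, would give a similar half-life.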